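Adding a triazolylmethyl group to the ring amine of compound 3

The source may hold more compounds than are shown below. What is called first, only, known or untested is meant among the compounds shown, and "the series" means these compounds.

Measured compounds:
- compound 1 `COc1ccccc1[C@H]1COC2(CCCNC2c2ccccc2)C1`: 6.5 nM
- compound 2 `COc1ccc(OC(F)(F)F)cc1[C@H]1COC2(CCCN[C@H]2c2ccccc2)C1`: 0.3 nM
- compound 3 `COc1ccc(-n2nnnc2C(F)(F)F)cc1[C@H]1COC2(CCCNC2c2ccccc2)C1`: 0.11 nM

In an assay on CHO cells for displacement of a labelled ligand from Substance-P receptor (Homo sapiens) (on this read-out lower numbers stand for stronger inhibition and higher numbers for weaker inhibition), compound 3 gives the lowest number of the three, with compound 2 nearest and compound 1 furthest. Compound 4 `COc1ccc(-n2nnnc2C(F)(F)F)cc1[C@H]1COC2(CCCN(Cc3n[nH]c(O)n3)C2c2ccccc2)C1` carries the change ((5-hydroxy-1H-1,2,4-triazol-3-yl)methyl in place of hydrogen on an amine nitrogen in a ring). Among the compounds with values here, none of the measured steps touches this amine nitrogen; the only single-change step, a 59-fold lower number from compound 1 to compound 3 (1.77 log units; beyond the scatter), concerns an aromatic carbon and so says little here. Within the data shown here, with no comparable step available, no move beyond the scatter is expected, and a step of a 1.4-fold higher number from compound 3 to compound 4 (0.13 log units; within the scatter) is estimated. Compound 4 is therefore expected to give about 0.15 nM in this assay, within a range from 0.04 nM to 0.6 nM.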

Compound 4, half-maximal inhibitory concentration: 0.1 nM
Compound 4: the middle estimate sits 1.5-fold (0.18 log units) above what was measured; the measured number falls inside the stated range.
By their numbers in this assay, from the lowest: compounds 4 and 3 (each within the scatter of the next); then compound 2; then compound 1.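

In this assay, within the data shown here, the earlier compounds all carry hydrogen on the amine nitrogen in a ring, so they say nothing about substitution there. With a 1.1-fold lower number from compound 3 to compound 4 (0.04 log units; within the scatter), the step stays within the scatter, showing that this nitrogen can bear (5-hydroxy-1H-1,2,4-triazol-3-yl)methyl, a group of 7 heavy atoms, without a measurable change in this read-out. Nothing measured here explains this result. Among these compounds, only this one group on the nitrogen appears, so it remains open whether a plain methyl, a longer carbon chain or a carboxylic acid would give a similar number.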